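Adding a Methyl Group to the Shared Core

A few compounds are considered here, and "the series" means these few. Any claim that something is new, unique, unknown or untested is made for them only; others in the source may bear on it.

Measured compounds:
compound 1 `NN1C(=O)C(c2ccccc2)CC(c2ccccc2)C1=O`: 76%
compound 2 `O=C1C(c2ccccc2)CC(c2ccccc2)C(=O)N1c1cccc(Cl)c1`: 32.2%
compound 3 `O=C1C(c2ccccc2Cl)CC(c2ccccc2Cl)C(=O)N1c1ccccc1`: 40.6%

In a functional assay on the whole organism (strain Swiss albino) for inhibition, with Mus musculus as the target, in the maximal electroshock model, with a stated time of 2 h, at a dose of 25 mg/kg by the intraperitoneal route (on this read-out lower numbers stand for less inhibition and higher numbers for more inhibition at the one dose given (going by the name of the read-out)), compound 1 gives 76%, compound 2 gives 32.2% and compound 3 gives 40.6%. Among these three numbers compound 3 holds the second highest place: its number lies within the usual scatter of that of compound 2, while it stands beyond the scatter below that of compound 1.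

Within the data shown here, the only step measured between two compounds differing in one place is a number 43.8 percentage points lower from compound 1 to compound 2 (beyond the scatter), where 3-chlorophenyl replaced amino on the amide-type nitrogen in the ring. That change is of a different kind from the one considered here and so does not bear on it.

Compound 4 `Cc1ccc(N2C(=O)C(c3ccccc3Cl)CC(c3ccccc3Cl)C2=O)cc1` differs from compound 3 by methyl in place of hydrogen on an aromatic carbon. Among the measured compounds shown here, no measured pair shows what this change does, so there is no ground for expecting a step in either direction; the expected step of a number 0.6 percentage points lower from compound 3 to compound 4 (within the scatter) is therefore estimated as none beyond the scatter. Compound 4 is expected to give about 40%, with a range from 20% to 60%.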

Compound 4, a percentage reported as inhibition, in the whole organism at one dose (the size of the read-out at that dose, not a potency): 58.2%
Estimate against measurement, compound 4: 18.2 percentage points below; the range from low to high includes it.
By their numbers in this assay, from the lowest: compounds 2 and 3 (each within the scatter of the next); then compound 4; then compound 1.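

In this assay, among these compounds, the change from phenyl to 4-methylphenyl gives a number 17.6 percentage points higher from compound 3 to compound 4 (beyond the scatter) and this is the first measured look at what a substituent does at this place. The earlier compounds shown here held no pair for this change, whereas this pair shows that a single methyl on an aromatic carbon, para to a large group, is enough to shift inhibition at the one dose given by more than ordinary scatter, and that the shift is upward. Nothing measured here bears on why the number rises.

As far as these compounds go, whether the rise belongs to methyl in particular, or would also come with another group at this place such as ethyl, methoxy or an amine, stays open, as does what methyl would do on a different carbon of the same ring. From the compounds shown here alone, the finding also rests on one pair that carries chlorophenyl groups on the shared core, so whether the same step would appear on a core with plain phenyl groups instead remains unknown.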